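Taking the Bromo off Compound 1

The source may report more compounds than this note shows. Statements on the series, on what has been measured and on what is new or still open speak of the compounds shown alone.

Measured in a functional assay, read by spectrophotometry, with a stated time of 6 min; on this read-out lower numbers stand for stronger inhibition and higher numbers for weaker inhibition:
Compound 1 `CCCCCCCCCCCCOc1cc(OC)c(Br)cc1C(C)=O`: 32700000 nM
Compound 2 `CCCCCCCCCCCCCCOc1cc(OC)c(Br)cc1C(C)=O`: 8700000 nM
Compound 3 `CCCCCCCCCCCCCCCCOc1cc(OC)c(Br)cc1C(C)=O`: 4600000 nM

Compound 1 has the highest number of the three, which makes it the weakest inhibitor measured. The gaps are a 3.8-fold lower number from compound 1 to compound 2 (0.58 log units; beyond the scatter) and a 7.1-fold lower number from compound 1 to compound 3 (0.85 log units; beyond the scatter). The remaining pair shows a 1.9-fold lower number from compound 2 to compound 3 (0.28 log units; within the scatter).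

Compound 4 `CCCCCCCCCCCCOc1cc(OC)ccc1C(C)=O` has not yet been measured and differs from compound 1 at a single place: hydrogen in place of bromo on an aromatic carbon. This is hydrogen in place of bromo on an aromatic carbon.

All three measured steps change the saturated chain, and every measured compound keeps the bromo. These steps therefore bear on the new change only indirectly, and their size cannot be carried over to it. The data give no direction for losing the bromo, so no step beyond the scatter is expected in this assay, although the uncertainty is wide. The expectation stays close to compound 1 at 32700000 nM. The estimated step is a 1.1-fold higher number from compound 1 to compound 4 (0.03 log units; within the scatter). For compound 4 the estimate is 35000000 nM, with an expected range of 10000000 nM to 100000000 nM.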

Compound 4, half-maximal inhibitory concentration: 40700000 nM
Compound 4: middle estimate off by 1.2-fold (0.07 log units), on the low side, within the range that was stated.
By their numbers in this assay, from the lowest: compounds 3 and 2 (each within the scatter of the next); then compounds 1 and 4 (each within the scatter of the next).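

In this assay, hydrogen in place of bromo on the aromatic carbon ortho to a methoxy group and meta to an acetyl group gives a 1.2-fold higher number from compound 1 to compound 4 (0.10 log units; within the scatter) and so stays within the scatter. Among these compounds, this is the first reading at this position: on the chain of compound 1, the bromo can be removed without a step that stands out from the scatter, and the shared core needs no halogen there to keep this level of inhibition. The earlier compounds all kept the bromo and varied only the saturated chain, where a 7.1-fold lower number from compound 1 to compound 3 (0.85 log units; beyond the scatter) remains beyond the scatter, so among the compounds shown the chain is the only place with such a step, and no evidence is available to explain the result at the bromo position.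

The compounds shown leave open whether hydrogen in place of bromo would read the same on the longer chains of compound 2 and compound 3. They also leave open whether another group on this aromatic carbon, such as an amine, a nitrile or a carboxylic acid, would move the number beyond the scatter.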